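Swapping One Aryl Group on the Aromatic Nitrogen

This account rests on a few compounds, and the source may have more. Where it says the series, first, only, none or still open, it means among the compounds named here.

Measured in a functional assay on A549 cells (Homo sapiens) for antiproliferative activity, read by MTT assay, with a stated time of 72 h; on this read-out higher numbers stand for weaker inhibition and lower numbers for stronger inhibition:
Compound 1 `CCNC(=O)c1cc(Oc2ccc(NC(=O)c3nn(-c4ccccc4OC(F)(F)F)c(=O)cc3C)cc2)ccn1`: 5280 nM
Compound 2 `CCNC(=O)c1cc(Oc2ccc(NC(=O)c3nn(-c4ccc(Br)cc4F)c(=O)cc3C)cc2)ccn1`: 34500 nM

Of the two measured compounds, compound 2 has the higher number at 34500 nM, which means the weaker inhibition. Compound 3 `CCNC(=O)c1cc(Oc2ccc(NC(=O)c3nn(-c4ccccc4C)c(=O)cc3C)cc2)ccn1` has not yet been measured. It carries 2-methylphenyl in place of 4-bromo-2-fluorophenyl on an aromatic nitrogen.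

Among the compounds with values here, only one measured step changes the group at this place: a 6.5-fold higher number from compound 1 to compound 2 (0.82 log units; beyond the scatter). This modest step lies beyond the scatter, and it brought 4-bromo-2-fluorophenyl in. Taking that group out again may therefore lower the number, although no measured compound carries 2-methylphenyl. A step of similar or smaller size is expected in this assay. The expected change is a 2.7-fold lower number from compound 2 to compound 3 (0.42 log units; beyond the scatter). For compound 3 the estimated value is 13000 nM, with an expected range of 4500 nM to 38000 nM.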

Compound 3, half-maximal inhibitory concentration: 34800 nM
Compound 3: middle estimate off by 2.7-fold (0.43 log units), on the low side, within the range that was stated.
By their numbers in this assay, from the lowest: compound 1; then compounds 2 and 3 (each within the scatter of the next).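

In this assay the swap of 4-bromo-2-fluorophenyl for 2-methylphenyl gives a 1.0-fold higher number from compound 2 to compound 3 (0.00 log units; within the scatter) and so separates neither group from the other at this place. The other new comparison is a 6.6-fold higher number from compound 1 to compound 3 (0.82 log units; beyond the scatter) and changes only the group on the aromatic carbon, so among these three compounds only compound 1, with its 2-(trifluoromethoxy)phenyl group, stands apart with the lower number. Nothing measured here explains why this group differs from the other two.

As far as these compounds go, it stays open whether the lower number of compound 1 depends on trifluoromethoxy specifically or would also appear with another group in its place. Plain phenyl, or a methoxy, trifluoromethyl or chlorine group in place of trifluoromethoxy, would help to answer that.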